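The source may report more compounds than this note shows. Statements on the series, on what has been measured and on what is new or still open speak of the compounds shown alone.

Compound 1, `C[C@H](NC(=O)c1c(C2CCC2)nnn1Cc1ccc(C(F)(F)F)cc1)c1ccc(C(=O)O)cc1`, gives 75.3 nM in a functional assay on CHO cells for antagonist activity at prostaglandin E2 receptor EP4 subtype (Homo sapiens), read by calcium flux, with a stated time of 15 min; on this read-out higher numbers stand for weaker inhibition and lower numbers for stronger inhibition.
Compound 2, `C[C@H](NC(=O)c1c(C2=CCOCC2)nnn1Cc1ccc(C(F)(F)F)cc1)c1ccc(C(=O)O)cc1`, gives 119 nM in this assay.
Compound 3, `C[C@H](NC(=O)c1c(-c2ccc(F)cc2)nnn1Cc1ccc(C(F)(F)F)cc1)c1ccc(C(=O)O)cc1`, gives 57.9 nM in this assay.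

Compound 3 has the lowest of the three numbers, yet only its gap to compound 2 lies beyond the scatter: a 2.1-fold lower number from compound 2 to compound 3 (0.31 log units; beyond the scatter). Against compound 1 the gap is within the scatter, a 1.3-fold lower number from compound 1 to compound 3 (0.11 log units; within the scatter), so these two cannot be ranked. Compound 4, `Cc1ccc(-c2nnn(Cc3ccc(C(F)(F)F)cc3)c2C(=O)N[C@@H](C)c2ccc(C(=O)O)cc2)s1`, differs from compound 3 in a single place: 5-methylthiophen-2-yl in place of 4-fluorophenyl on an aromatic carbon. Both measured steps concern this same position of the shared core. Going from a four-membered non-aromatic ring to a six-membered aromatic ring gave a 1.3-fold lower number from compound 1 to compound 3 (0.11 log units; within the scatter), and going from a six-membered non-aromatic ring gave a 2.1-fold lower number from compound 2 to compound 3 (0.31 log units; beyond the scatter). Among the compounds with values here, exchanging one aromatic ring for another aromatic ring is a smaller alteration than either of these, and no measured step shows what a ring containing sulfur does at this position. The expected step in this assay is therefore none beyond the scatter, a 1.0-fold higher number from compound 3 to compound 4 (0.02 log units; within the scatter). Compound 4 is estimated at 60 nM, with a range from 25 nM to 150 nM.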

Compound 4, half-maximal inhibitory concentration: 4.6 nM
For compound 4 the middle estimate is 13-fold (1.12 log units) above the measured one, and the stated range ends above it.
By their numbers in this assay, from the lowest: compound 4; then compounds 3, 1 and 2 (each within the scatter of the next, the first and the last beyond it).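

Swapping one aromatic ring for another at this position of the shared core is not the minor change that the earlier compounds suggested: in this assay, 5-methylthiophen-2-yl gives a 13-fold lower number from compound 3 to compound 4 (1.10 log units; beyond the scatter) and stands well clear of the two non-aromatic groups as well, with a 16-fold lower number from compound 1 to compound 4 (1.21 log units; beyond the scatter) and a 26-fold lower number from compound 2 to compound 4 (1.41 log units; beyond the scatter) as the other two steps. Within the data shown here, the single change brings in a five-membered ring, a sulfur atom and a methyl group all at once, so these compounds cannot separate their contributions. Nothing available here gives a reason for the size of these steps.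

On these data alone, it remains open whether an unsubstituted thiophen-2-yl group or a 4-methylphenyl group would give a number close to that of compound 4. Also open, as far as these compounds go, is what an ethyl group or an amine in place of the methyl would do.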